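The source may hold more compounds than are shown below. What is called first, only, known or untested is meant among the compounds shown, and "the series" means these compounds.

Compound 1 `Cc1ccc(C(/C=C/c2ccc(F)cc2)=N\Nc2nncc3ccccc23)cc1` and compound 2 `O=S(=O)(Nc1ccccn1)c1ccc(Nc2nncc3ccccc23)cc1` share one core and were both run in a functional assay on SK-OV-3 cells (Homo sapiens) for antiproliferative activity, read by sulforhodamine B assay, with a stated time of 72 h; on this read-out lower numbers stand for stronger inhibition and higher numbers for weaker inhibition. In this assay compound 1 gives 0.07 nM. In this assay compound 2 gives 0.9 nM, the higher of the two numbers, a gap beyond the usual scatter. Compound 3 `NS(=O)(=O)c1ccc(Nc2nncc3ccccc23)cc1` is not yet measured. It differs from compound 2 in one place: hydrogen in place of pyridin-2-yl on a sulfonamide nitrogen. For the measured compounds named here, no measured pair covers this change, so the expectation rests on compound 2 alone. A small step toward a higher number is expected, a 2.2-fold higher number from compound 2 to compound 3 (0.35 log units; beyond the scatter), near the edge of the scatter. Compound 3 is estimated at 2 nM, within 0.4 nM to 10 nM.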

Compound 3, half-maximal inhibitory concentration: 0.8 nM
The estimate for compound 3 lay 2.5-fold (0.40 log units) above the measured number; low and high end bracket the measured number.
By their numbers in this assay, from the lowest: compound 1; then compounds 3 and 2 (each within the scatter of the next).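

Hydrogen in place of pyridin-2-yl on the sulfonamide nitrogen gives a 1.1-fold lower number from compound 2 to compound 3 (0.05 log units; within the scatter) in this assay. At this position, then, the pyridin-2-yl group is not needed for the low nanomolar read-out, and the sulfonamide with a free nitrogen reads the same as the substituted one. Nothing available here offers an explanation for this.

Going by these compounds, whether this tolerance extends to other groups on that nitrogen, such as methyl, acetyl or a longer alkyl chain, remains open. Also open, on these data alone, is whether a carboxylic acid in place of the whole sulfonamide would keep the read-out.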